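The compounds below may be only part of what the source reports. "The series", "measured", "known", "first", "only" and "open" are said of these compounds alone.

Compound 1, `Cc1ccc(-n2cc(C(=O)Nc3cc(F)cc(F)c3)c(=O)c3ccc(N(C)C)nc32)cc1OCCCCCCC[N+]1(C)CCCCC1`: 23.4%
Compound 2, `CN(C)c1ccc2c(=O)c(C(=O)Nc3cc(F)cc(F)c3)cn(-c3ccc(Cl)c(OCCCCCCC[N+]4(C)CCCCC4)c3)c2n1`: 57.3%
Compound 3, `CC[N+]1(CCCCCCCOc2ccc(-n3cc(C(=O)Nc4cc(F)cc(F)c4)c(=O)c4ccc(N(C)C)nc43)cc2C)CCCCC1`: 19.7%

These values come from an assay on LX2 cells for inhibition of COL1A1 promoter (Homo sapiens), read by a luciferase reporter, with a stated time of 24 h, tested at 20 uM; a lower number here means a weaker effect, a higher number a stronger effect of the compound at the concentration tested. The change from compound 1 to compound 2 is chloro in place of methyl on an aromatic carbon, and it made a number 33.9 percentage points higher from compound 1 to compound 2 (beyond the scatter). Compound 4, `CC[N+]1(CCCCCCCOc2ccc(-n3cc(C(=O)Nc4cc(F)cc(F)c4)c(=O)c4ccc(N(C)C)nc43)cc2Cl)CCCCC1`, has not been measured; it arises from compound 3 by chloro in place of methyl on an aromatic carbon. How the core of compound 3 differs from the core of compound 1 is not broken down here. The two changes are the same kind of change, yet their surroundings differ: in compound 2 the chloro is ortho to a large group and para to a large group, in compound 4 ortho to a large group and meta to a large group. Compound 3 and compound 1 lie within the scatter of each other. Resting on the earlier step, the step from compound 3 to compound 4 is expected to be a number 25.3 percentage points higher from compound 3 to compound 4 (beyond the scatter), set a little below that earlier step since the place differs. Compound 4 is therefore estimated at 45%, between 25% and 65%.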

Compound 4, a percentage reported as inhibition, at one concentration (the size of the read-out at that concentration, not a potency): 14.3%
Compound 4: middle estimate off by 30.7 percentage points, on the high side; measured number outside the range, below it.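

In this assay, putting chloro in place of methyl on the core of compound 3 gave a number 5.4 percentage points lower from compound 3 to compound 4 (within the scatter), so the large rise seen on the core of compound 1 did not appear here. The same change therefore behaved differently on the two cores: the same change on two cores in this assay, a number 33.9 percentage points higher (beyond the scatter) from compound 1 to compound 2 and a number 5.4 percentage points lower (within the scatter) from compound 3 to compound 4, 39.3 percentage points apart, beyond the scatter of two such steps

A gain from this change cannot be assumed on a new core in this series, though two pairs cannot show why the steps part or predict the outcome on any further core. Still open, from the compounds shown here alone, is whether a bromo or a trifluoromethyl group on the same aromatic carbon would follow the chloro on either core. Also open, going by these compounds, is whether a hydrogen there would give a number close to that of the methyl or the chloro compounds.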